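A Methyl Added to the Core of Compound 3

The source may report more compounds than this note shows. Statements on the series, on what has been measured and on what is new or still open speak of the compounds shown alone.

Three measured compounds share a core and differ in one region. Compound 1 `CCn1cc(Nc2ncc3cccc(-c4ccc(OC)cc4)c3n2)cn1` and compound 2 `CCn1cc(Nc2ncc3cccc(Nc4ccc(OC)cc4)c3n2)cn1` carry a 4-methoxyphenyl or a (4-methoxyphenyl)amino group on an aromatic carbon, while compound 3 `CCn1cc(Nc2ncc3cnn(-c4ccc(OC)cc4)c3n2)cn1` carries its 4-methoxyphenyl group on a different part of a five-membered ring of the core. In an assay on isolated protein for inhibition of eIF-2-alpha kinase GCN2 (Homo sapiens) (on this read-out higher numbers stand for weaker inhibition and lower numbers for stronger inhibition), compound 1 reaches only the limit of the assay, > 1000 nM. Compound 2 likewise stops at a limit, > 1000 nM. The step that the two limits leave unreadable from compound 1 to compound 2 cannot be read because both ends sit at the limit of > 1000 nM in this assay, at which 2 of the 3 values shown sit. For the measured compounds named here, compound 3 is the only compound with a number, 133 nM, and so stands alone as the single reading.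

Compound 4 `CCn1cc(Nc2ncc3c(C)nn(-c4ccc(OC)cc4)c3n2)cn1` differs from compound 3 by one change: methyl in place of hydrogen on an aromatic carbon. No measured step adds a methyl to this ring, so none of the steps shown bears directly on it. A change this small is expected to give a 1.0-fold lower number from compound 3 to compound 4 (0.01 log units; within the scatter), a step within the scatter and in no particular direction. Compound 4 is therefore estimated at 130 nM, in the range 40 nM to 400 nM.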

Compound 4, half-maximal inhibitory concentration: 81 nM
For compound 4 the middle estimate is 1.6-fold (0.21 log units) above the measured one, and the stated range covers the measured number.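

In this assay methyl in place of hydrogen gives a 1.6-fold lower number from compound 3 to compound 4 (0.22 log units; within the scatter) and so, on this aromatic carbon next to the ring nitrogen, the added methyl leaves compound 4 indistinguishable from compound 3 within the usual scatter. For the compounds shown here, this is the first step that can be read as a number, and it shows that this carbon of the five-membered aromatic ring can carry one extra carbon without a measurable loss of inhibition. None of the information shown gives a measured property that bears on this result.

A longer chain such as ethyl or propyl, or a group of another kind such as an amine or a carboxylic acid, remains untested on this carbon among the compounds shown. From the compounds shown here alone, how far this position accepts larger groups therefore stays open.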